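The source may report more compounds than this note shows. Statements on the series, on what has been measured and on what is new or still open speak of the compounds shown alone.

Compound 1 `c1cc(-c2noc(C3CC3)n2)ccc1C1=NCCN1` gives 7370 nM in an assay for inhibition of Amine oxidase [flavin-containing] A (Homo sapiens), read by fluorescence and spectrophotometry, using microsomes, with stated times of 30 min and 20 min; a higher number here means a weaker inhibitor, a lower number a stronger inhibitor.
Compound 2 `Cc1ccc(-c2nc(-c3ccc(C4=NCCN4)cc3)no2)cc1` gives 2310 nM in this assay.
Compound 3 `Clc1cccc(-c2nc(-c3cccc(C4=NCCN4)c3)no2)c1` gives 1390 nM in this assay.

Compound 3 shows the lowest number of the three, though compound 2 lies within the scatter of it; only compound 1 sits clearly higher. Compound 4 `c1cc(C2=NCCN2)cc(-c2noc(-c3cccs3)n2)c1` differs from compound 3 by thiophen-2-yl in place of 3-chlorophenyl on an aromatic carbon. Going by the values given here, the one measured step at this position, a 3.2-fold lower number from compound 1 to compound 2 (0.50 log units; beyond the scatter), replaces cyclopropyl with an aromatic ring; the present change exchanges one aromatic ring for another, and compounds 2 and 3, each bearing an aromatic ring there, lie within the scatter of each other. No step beyond the scatter is therefore expected in this assay for compound 4. Compound 4 is estimated at 2000 nM, between 900 nM and 4500 nM, which means an expected 1.4-fold higher number from compound 3 to compound 4 (0.16 log units; within the scatter).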

Compound 4, half-maximal inhibitory concentration: 88300 nM
Compound 4: middle estimate off by 44-fold (1.64 log units), on the low side, outside the stated range (above it).
By their numbers in this assay, from the lowest: compounds 3 and 2 (each within the scatter of the next); then compound 1; then compound 4.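

In this assay the choice of aromatic ring on this carbon matters: thiophen-2-yl in place of 3-chlorophenyl gives the largest change in the series (a 64-fold higher number from compound 3 to compound 4 (1.80 log units; beyond the scatter)). The earlier step (a 3.2-fold lower number from compound 1 to compound 2 (0.50 log units; beyond the scatter)) ran the opposite way, so an aromatic ring here does not by itself bring a lower number. Nothing at hand accounts for this step.

Still open, as far as these compounds go, is whether the chlorine or the six-membered ring carries the difference. Unsubstituted phenyl or thiophen-3-yl on the core of compound 3 would separate these.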